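A few compounds are considered here, and "the series" means these few. Any claim that something is new, unique, unknown or untested is made for them only; others in the source may bear on it.

Measured compounds, with their numbers in a functional assay on A549 cells (Homo sapiens) for antiproliferative activity, read by MTT assay, with a stated time of 72 h; a lower number here means a stronger inhibitor, a higher number a weaker inhibitor:
compound 1 `CN(C(=O)c1ccc(Cl)cc1)c1ccc2[nH]c(-c3n[nH]c4ccccc34)cc2n1`: 2220 nM
compound 2 `CN(C(=O)c1ccc(Br)cc1)c1ccc2[nH]c(-c3n[nH]c4ccccc34)cc2n1`: 4250 nM
compound 3 `CN(C(=O)c1ccc([N+](=O)[O-])cc1)c1ccc2[nH]c(-c3n[nH]c4ccccc34)cc2n1`: 34500 nM

Compound 2 sits second highest of the three numbers. Its nearest neighbour is compound 1, and the step of a 1.9-fold higher number from compound 1 to compound 2 (0.28 log units; within the scatter) lies within the scatter, so the two cannot be ordered. Compound 3 is furthest away, the step of an 8.1-fold higher number from compound 2 to compound 3 (0.91 log units; beyond the scatter) being modest and beyond the scatter; the step of a 16-fold higher number from compound 1 to compound 3 (1.19 log units; beyond the scatter) is large.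

Compound 4 `Cc1ccc(S(=O)(=O)N(C)c2ccc3[nH]c(-c4n[nH]c5ccccc45)cc3n2)cc1` differs from compound 2 in one place: (4-methylphenyl)sulfonyl in place of (4-bromophenyl)carbonyl on a nitrogen on an aromatic ring. Within the data shown here, no measured step swaps the carbonyl for a sulfonyl; the three steps only replace the group on the phenyl ring, where halide for halide changed little and nitro for halide weakened the compound clearly. The new change alters both the linking group and the ring substituent, so the measured steps bear on it only loosely. In this assay the expected step from compound 2 to compound 4 is a 1.4-fold higher number from compound 2 to compound 4 (0.15 log units; within the scatter), with no direction beyond the scatter that can be defended, and a wide range to cover the unmeasured linker change.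

The estimate for compound 4 in this assay is 6000 nM, expected to fall between 1500 nM and 25000 nM.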

Compound 4, half-maximal inhibitory concentration: 27100 nM
Compound 4: middle estimate off by 4.5-fold (0.65 log units), on the low side; measured number outside the range, above it.
By their numbers in this assay, from the lowest: compounds 1 and 2 (each within the scatter of the next); then compounds 4 and 3 (each within the scatter of the next).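

In this assay, the group on the nitrogen on an aromatic ring can now be seen to move the number through more than a change of halide: (4-methylphenyl)sulfonyl in place of the carbonyl-linked halophenyl groups gives a 6.4-fold higher number from compound 2 to compound 4 (0.80 log units; beyond the scatter) and a 12-fold higher number from compound 1 to compound 4 (1.09 log units; beyond the scatter), both beyond the scatter, whereas the bromo and chloro compounds could not be ordered. Until now, only the nitro group of compound 3 had given a number clearly above those of the two halides, so compound 4 shows that a nitro group is not needed for such a rise, and compound 4 and compound 3 lie within the scatter of each other. Nothing available explains these steps, which therefore stand only as observed differences in the number.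

On these data alone, the change replaces the linking group and the ring substituent together, so the share of each stays open, and (4-methylphenyl)carbonyl or (4-bromophenyl)sulfonyl would separate the two. As far as these compounds go, how an amine or a carboxylic acid on the phenyl ring would fall with either linking group is also open.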